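Removing the ring methyl from the thiazole of compound 3

This account rests on a few compounds, and the source may have more. Where it says the series, first, only, none or still open, it means among the compounds named here.

Measured so far in an ADME assay on MDCK cells (Canis lupus familiaris) for cytotoxicity, read by microscopy, with a stated time of 48 h; on this read-out higher numbers stand for lower toxicity in this test and lower numbers for higher toxicity in this test:
- compound 1 `C[C@H]1[C@H](NCc2cncnc2)C[C@H]2C[C@@H]1C2(C)C`: > 100000 nM
- compound 2 `C[C@H]1[C@H](NCc2ccco2)C[C@H]2C[C@@H]1C2(C)C`: 50000 nM
- compound 3 `Cc1csc(CN[C@@H]2C[C@H]3C[C@@H]([C@H]2C)C3(C)C)n1`: > 100000 nM

The value of compound 1 is a limit, not a number. The value of compound 3 is likewise a limit. Compound 2 alone gives a number; the step of an at least 2.0-fold lower number from compound 1 to compound 2 (0.30 log units; that floor lies within the scatter) and the step of an at least 2.0-fold higher number from compound 2 to compound 3 (0.30 log units; that floor lies within the scatter) both rest on that one number against a limit, and the step that the two limits leave unreadable from compound 1 to compound 3 is not readable. Compound 3 thus stands at the limit of > 100000 nM in this assay, at which 2 of the 3 values shown sit.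

Compound 4 `C[C@H]1[C@H](NCc2nccs2)C[C@H]2C[C@@H]1C2(C)C` differs from compound 3 by hydrogen in place of methyl on an aromatic carbon. Within the data shown here, no measured step concerns a methyl on the heteroaryl; all three swap one heteroaryl for another. The expected step of a number no higher from compound 3 to compound 4 (the limit leaves the size open) is therefore none beyond the scatter. Compound 4 is estimated at 100000 nM, between 50000 nM and 200000 nM.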

Compound 4, minimum cytotoxic concentration: > 100000 nM
Compound 4: a limit, no number; the forecaster's own chance of this, stated with the estimate: 60%; the middle value sits exactly at the limit.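

In this assay compound 4 gives a limit and not a number, so the methyl on the thiazole is not needed to reach this limit: the limit of > 100000 nM in this assay, at which 3 of the 4 values shown sit. The steps to compound 3 and to compound 1 cannot be read, so any effect of the methyl stays hidden. Among these compounds, the only readable step is an at least 2.0-fold higher number from compound 2 to compound 4 (0.30 log units; that floor lies within the scatter).

Going by these compounds, whether an ethyl or a carboxylic acid on this aromatic carbon gives a number rather than a limit stays open. So does how far compounds 1, 3 and 4 differ from one another.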